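Aryl ester swap carried onto the pyridin-4-yl core

This account rests on a few compounds, and the source may have more. Where it says the series, first, only, none or still open, it means among the compounds named here.

Compound 1 `CC(C)c1cccc(OC(=O)c2cn(-c3ccccc3)nc2-c2cccnc2)c1` is the reference point of this small set. In a functional assay on Raji cells (Homo sapiens) for cytotoxicity, read by MTT assay, with a stated time of 48 h (on this read-out lower numbers stand for stronger inhibition and higher numbers for weaker inhibition), compound 1 gives 11600 nM. Compound 2 `CC(C)(C)c1ccc(OC(=O)c2cn(-c3ccccc3)nc2-c2cccnc2)cc1` carries 4-(tert-butyl)phenyl in place of 3-isopropylphenyl on an oxygen next to a carbonyl group, and in this assay compound 2 gives 42300 nM, which is a 3.6-fold higher number from compound 1 to compound 2 (0.56 log units; beyond the scatter).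

Compound 3 `CC(C)c1cccc(OC(=O)c2cn(-c3ccccc3)nc2-c2ccncc2)c1` differs from compound 1 in the core by pyridin-4-yl in place of pyridin-3-yl on an aromatic carbon. In this assay compound 3 is recorded as "nd(insoluble)" (no result reported), so no number stands for it. Compound 4 `CC(C)(C)c1ccc(OC(=O)c2cn(-c3ccccc3)nc2-c2ccncc2)cc1` is the unmeasured member and carries, relative to compound 3, (4-(tert-butyl)phenyl in place of 3-isopropylphenyl on an oxygen next to a carbonyl group). The place of this change is the same word for word as for the change from compound 1 to compound 2, so it is the same change, and among the four compounds it occurs twice.

Any expectation for compound 4 has to rest on the measured pair. Among the compounds with values here, the one measured instance of the change is a 3.6-fold higher number from compound 1 to compound 2 (0.56 log units; beyond the scatter), a step beyond the scatter, and compound 4 has the same core as compound 3, which left no number. In this assay compound 4 is therefore expected near 45000 nM, because compound 2 gives 42300 nM with the same ester group. The range for compound 4 is estimated from 12000 nM to 160000 nM, wide since compound 3 supplied no anchoring value.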

Compound 4, half-maximal inhibitory concentration: 33300 nM
Estimate against measurement, compound 4: 1.4-fold (0.13 log units) above, and the stated range covers the measured number.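

In this assay the core change with the 4-(tert-butyl)phenyl ester held fixed gives a 1.3-fold lower number from compound 2 to compound 4 (0.10 log units; within the scatter), so on this one ester the two cores cannot be told apart and the pyridin-4-yl in place of pyridin-3-yl leaves the number within the usual scatter. The aryl ester swap itself has a single reading, a 3.6-fold higher number from compound 1 to compound 2 (0.56 log units; beyond the scatter), and the matching step from compound 3 to compound 4 cannot be read since compound 3 has no number, so the data do not show whether the swap carries over to the second core with the same size or even the same direction. Nothing at hand gives a measured reason for either step, and this small set offers no explanation of the numbers.

Still open, on these data alone, is whether the 3-isopropylphenyl ester on the core of compound 3 would stand apart from the 4-(tert-butyl)phenyl ester of compound 4 if a number for compound 3 could be had. Also open, as far as these compounds go, is how this assay would respond to an aryl group carrying an amine or a carboxylic acid, or to an amide in place of the ester link.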